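Adding a Second Fluoro to Compound 3

A few compounds are considered here, and "the series" means these few. Any claim that something is new, unique, unknown or untested is made for them only; others in the source may bear on it.

Compound 3 `Oc1cc(C(F)(F)F)ccc1-c1nc(-c2ccccc2O)n(-c2cccc(F)c2)n1` was tested in a functional assay on PC-12 cells (Rattus norvegicus) for cytotoxicity, read by MTT assay, with stated times of 2 h and 24 h, tested at 5 uM (on this read-out lower numbers stand for a weaker effect and higher numbers for a stronger effect at the one concentration tested), where compound 3 gives 87.7%. Compound 1 `CCc1ccc(-n2nc(-c3ccc(C(F)(F)F)cc3O)nc2-c2ccccc2O)cc1` gives 95.4% and compound 2 `Oc1cc(C(F)(F)F)ccc1-c1nc(-c2ccccc2O)n(-c2ccc(F)cc2)n1` gives 86.7%; on these three numbers compound 3 stands second highest, nearest to compound 2 and furthest from compound 1, with both gaps within the scatter. Compound 4 `Oc1cc(C(F)(F)F)ccc1-c1nc(-c2ccccc2O)n(-c2cc(F)cc(F)c2)n1` has not yet been measured. It differs from compound 3 by fluoro in place of hydrogen on an aromatic carbon. For the measured compounds named here, two measured steps bear on this change, as each alters the aryl group on the aromatic nitrogen: a number 7.7 percentage points lower from compound 1 to compound 3 (within the scatter) and a number 1 percentage points higher from compound 2 to compound 3 (within the scatter). Neither leaves the scatter. Nothing among the three measured compounds indicates that a further fluoro in this position would shift the read-out beyond the scatter, so the step of a number 0.3 percentage points higher from compound 3 to compound 4 (within the scatter) is expected to be small. Compound 4 is estimated at 88%, within a range from 78% to 96%.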

Compound 4, a percentage reported as activity, at one concentration (the size of the read-out at that concentration, not a potency): 100%
Beside the measured number, compound 4's estimate is 12 percentage points below it; the measured number lies above the stated range.
By their numbers in this assay, from the lowest: compounds 2, 3, 1 and 4 (each within the scatter of the next, the first and the last beyond it).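

In this assay, for the compounds shown here, fluoro in place of hydrogen on the 3-fluorophenyl group gives a number 12.3 percentage points higher from compound 3 to compound 4 (beyond the scatter) and so passes the scatter, which no step among compounds 1, 2 and 3 did, showing that this aromatic carbon can register a change in this read-out. The 3,5-difluorophenyl group likewise separates from the 4-fluorophenyl group, with a number 13.3 percentage points higher from compound 2 to compound 4 (beyond the scatter) as the step, whereas a number 4.6 percentage points higher from compound 1 to compound 4 (within the scatter) stays within the scatter, so the 3,5-difluorophenyl and 4-ethylphenyl groups cannot be ordered. Nothing available offers a reason for this rise.

The compounds shown leave open whether this step is particular to fluoro or would also appear with a chloro, a methoxy or an amine on the same carbon. They also leave open how the 3,5-difluorophenyl group would behave at concentrations other than the one tested.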